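The compounds below may be only part of what the source reports. "The series", "measured", "known", "first", "only" and "open" are said of these compounds alone.

Measured so far:
- compound 1 `CCCC1=C(OC)C(CCC)(CCC)C(=O)/C(=C(O)\C=C\c2ccc(I)cc2)C1=O`: 2.8 uM
- compound 2 `CCCC1=C(OC)C(CCC)(CCC)C(=O)/C(=C(O)\C=C\c2ccc(Br)cc2)C1=O`: 4.7 uM

Both compounds share one core and were tested in a functional assay on PC-3 cells (Homo sapiens) for antiproliferative activity, read by sulforhodamine B assay, with a stated time of 3 days; on this read-out higher numbers stand for an effect only at larger amounts of compound and lower numbers for an effect already at smaller amounts. For the measured compounds named here, compound 1 provides the smaller of the two figures, but the only measured step, a 1.7-fold higher number from compound 1 to compound 2 (0.22 log units; within the scatter), lies within the scatter, so the two compounds cannot really be told apart on this read-out.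

Compound 3 `CCCOC1=C(CCC)C(=O)/C(=C(O)/C=C/c2ccc(I)cc2)C(=O)C1(CCC)CCC` has not yet been tested in this assay. It differs from compound 1 in a single place: ethyl in place of hydrogen on a saturated chain carbon bound to an oxygen on an unsaturated carbon. Going by the values given here, no measured step touches this part of the molecule; the one step available, a 1.7-fold higher number from compound 1 to compound 2 (0.22 log units; within the scatter), concerns a halogen on the aromatic ring and is itself within the scatter, so it offers no direction for a change at the alkoxy group. With nothing pointing either way, the expectation for compound 3 is a number close to that of compound 1, and the step of a 1.3-fold higher number from compound 1 to compound 3 (0.10 log units; within the scatter) is estimated to stay within the scatter. Compound 3 is therefore expected to give about 3.5 uM in this assay, with a likely range from 1.2 uM to 10 uM.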

Compound 3, concentration for half-maximal effect: 9.6 uM
The estimate for compound 3 lay 2.7-fold (0.44 log units) below the measured number; measured number inside the range.
By their numbers in this assay, from the lowest: compounds 1 and 2 (each within the scatter of the next); then compound 3.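

In this assay, for the compounds shown here, the change from methoxy to propoxy brings a 3.4-fold higher number from compound 1 to compound 3 (0.54 log units; beyond the scatter) and is the first step in this small set to stand clear of the usual scatter. The swap of iodo for bromo on the aromatic carbon, with a 1.7-fold higher number from compound 1 to compound 2 (0.22 log units; within the scatter) as its step, could not be told apart from repeat-to-repeat variation, whereas ethyl in place of hydrogen on a saturated chain carbon bound to an oxygen on an unsaturated carbon does shift the number, modestly and towards needing more compound. So this position responds to what is placed on it, yet nothing at hand gives a measured property that would account for the shift.

A single pair cannot show whether the number climbs steadily with chain length, which an ethoxy or a butoxy group at the same oxygen would help to settle, or whether the same change acts alike on the bromo compound. On these data alone, it also remains open how this position would respond to a different kind of group on the chain, such as an amine or a carboxylic acid at its end.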